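The source may hold more compounds than are shown below. What is called first, only, known or untested is meant among the compounds shown, and "the series" means these compounds.

Values so far in (a functional assay on KMS-11 cells (Homo sapiens) for antiproliferative activity, read by CellTiter-Glo, with a stated time of 72 h; a lower number here means a stronger inhibitor, a higher number a weaker inhibitor) are as follows.
- compound 1 (`COc1ccc(C(=O)N(Cc2ccncc2)Cc2cccc(OCCc3cccc(C(F)(F)F)c3)c2)cc1`) gives (8900 nM)
- compound 2 (`COc1ccc(C(=O)N(Cc2ccncc2)Cc2cccc(OCC3CCOCC3)c2)cc1`) gives (17700 nM)
- compound 3 (`COc1ccc(C(=O)N(Cc2ccncc2)Cc2cccc(OCC3CCN(C(=O)OC(C)(C)C)CC3)c2)cc1`) gives (5100 nM)

Compound 2 (17700 nM) lies within the scatter of compound 1 (8900 nM). Compound 3 (5100 nM) shows a lower number than compound 2, and that gap lies beyond the scatter.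

The next compound is compound 4 (`COc1ccc(C(=O)N(Cc2ccncc2)Cc2cccc(OCC3CCCCC3)c2)cc1`), which carries cyclohexyl in place of oxan-4-yl on a saturated chain carbon bound to an oxygen on an aromatic ring. Cut one bond further out, the same difference reads (oxan-4-yl)methoxy to cyclohexylmethoxy.

Within the data shown here, only one measured step falls at this place (a 2.0-fold higher number from compound 1 to compound 2 (0.30 log units; within the scatter)), with oxan-4-yl in place of 3-(trifluoromethyl)benzyl, and it stays within the scatter. Among the measured compounds shown here, no measured pair isolates the exchange of oxan-4-yl for cyclohexyl.

In (this assay) a small step is therefore expected, within the scatter and leaning towards a lower number, with compound 3 (5100 nM) showing that a lower number is reachable through a change at this place. The expected step is (a 1.6-fold lower number from compound 2 to compound 4 (0.21 log units; within the scatter)). Compound 4 is estimated at (11000 nM), with an expected range from (5000 nM) to (22000 nM).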

Compound 4, half-maximal inhibitory concentration: 19700 nM
Beside the measured number, compound 4's estimate is 1.8-fold (0.25 log units) below it, within the range that was stated.
By their numbers in this assay, from the lowest: compounds 3, 1, 2 and 4 (each within the scatter of the next, the first and the last beyond it).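

In this assay, exchanging the oxan-4-yl of the (oxan-4-yl)methoxy group for cyclohexyl gives a 1.1-fold higher number from compound 2 to compound 4 (0.05 log units; within the scatter), so at this place the series tolerates loss of the ring oxygen and its hydrogen-bond acceptor with no step beyond the scatter. Exchanging the 3-(trifluoromethyl)benzyl group for cyclohexyl at the same place gives a 2.2-fold higher number from compound 1 to compound 4 (0.35 log units; beyond the scatter), a modest step, although the step to oxan-4-yl stayed within the scatter and the two six-membered rings cannot be told apart, so this separation is slight and rests on a single pair. Nothing measured here accounts for these steps, and no independent data on the groups bear on them.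

Compound 3, at 5100 nM, remains the only compound with a value beyond the scatter of both compound 2 and compound 4, and the compounds shown leave open which part of its larger substituent matters, such as whether the ring nitrogen alone as a free amine would hold that value. Also open, from the compounds shown here alone, is how a carboxylic acid, an amide or a longer chain on the saturated carbon bound to the aromatic ether oxygen would read in this assay, since every value so far lies in a narrow, weak range.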